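The source may hold more compounds than are shown below. What is called first, only, known or untested is meant among the compounds shown, and "the series" means these compounds.

Three compounds of the series have been run in a functional assay on T98G cells (Homo sapiens) for inhibition, read by colorimetric assay and MTT assay, with a stated time of 72 h (a higher number here means a weaker inhibitor, a lower number a stronger inhibitor), so far. Compound 1 `C=CCCCCOc1cc2ccccc2cc1-c1cnc(OCCC=C)n1C` gives 32000 nM in this assay. Compound 2 `C=CCCCCOc1cc2ccccc2cc1-c1cnc(OCCCCC=C)n1C` gives 40000 nM in this assay; the change from compound 1 to compound 2 is but-3-en-1-yl in place of vinyl on a saturated chain carbon, two bonds along the chain from an oxygen on an aromatic ring, and it made a 1.3-fold higher number from compound 1 to compound 2 (0.10 log units; within the scatter). Compound 3 `C=CCCOc1ncc(-c2ccccc2OC)n1C` is built on another core and gives 39000 nM in this assay; the difference between the core of compound 3 and the core of compound 1 is not broken down here, and the values of compound 3 and compound 2 lie within the scatter of each other, as do those of compound 3 and compound 1.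

Compound 4 `C=CCCCCOc1ncc(-c2ccccc2OC)n1C` is not yet measured. It differs from compound 3 by but-3-en-1-yl in place of vinyl on a saturated chain carbon, two bonds along the chain from an oxygen on an aromatic ring, the same change as from compound 1 to compound 2, at the same place. Compound 4 is expected to show a step of a 1.2-fold higher number from compound 3 to compound 4 (0.06 log units; within the scatter) in this assay. This rests on compound 1 and compound 2, whose step a 1.3-fold higher number from compound 1 to compound 2 (0.10 log units; within the scatter) stayed within the scatter. Compound 4 is thus estimated at 45000 nM in this assay, most likely between 20000 nM and 100000 nM.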

Compound 4, half-maximal inhibitory concentration: 5000 nM
Compound 4: middle estimate off by 9.0-fold (0.95 log units), on the high side; the whole stated range lies above it.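

In this assay, but-3-en-1-yl in place of vinyl gives a 7.8-fold lower number from compound 3 to compound 4 (0.89 log units; beyond the scatter), so this change does not carry over with the same result from one core to the other. The size of the step depends on the core in this comparison: the same change on two cores in this assay, a 1.3-fold higher number (0.10 log units; within the scatter) from compound 1 to compound 2 and a 7.8-fold lower number (0.89 log units; beyond the scatter) from compound 3 to compound 4, 9.8-fold (0.99 log units) apart, beyond the scatter of two such steps This shows that a step read on the core of compound 1 is a poor guide to the same change on the core of compound 3, but it rests on a single pair on each core and gives no general rule. The two cores differ in more than one place, and the data do not show which part of them decides the outcome.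

As far as these compounds go, it remains open whether the lower number on the core of compound 3 persists with a chain longer than (hex-5-en-1-yl)oxy or with a saturated hexyloxy chain lacking the double bond. A third core carrying the same vinyl and but-3-en-1-yl pair could show which of the two steps is more typical of the series.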